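A few compounds are considered here, and "the series" means these few. Any claim that something is new, unique, unknown or untested is made for them only; others in the source may bear on it.

Measured compounds and their values in an assay on Sf9 cells for inhibition of protein deacetylase HDAC6 (Homo sapiens), read by fluorescence, with a stated time of 40 min, tested at 100 nM; a higher number here means more inhibition at the concentration tested (going by the name of the read-out), a lower number less inhibition:

Compound 1, `COc1ccc(-c2nc(CNc3ccc(C(=O)NO)cc3)n(-c3ccccc3)n2)cc1`: compound 1 gives 77.6%
Compound 2, `O=C(NO)c1ccc(NCc2nc(-c3ccc(Br)o3)nn2-c2ccccc2)cc1`: compound 2 gives 55.8%
Compound 3, `O=C(NO)c1ccc(NCc2nc(-c3ccc(C(F)(F)F)cc3)nn2-c2ccccc2)cc1`: compound 3 gives 41.6%

On these numbers compound 3 stands lowest. Its nearest neighbour is compound 2, and the change from compound 2 to compound 3 was a number 14.2 percentage points lower from compound 2 to compound 3 (beyond the scatter). The gap to compound 1 is wider, since the change from compound 1 to compound 3 was a number 36 percentage points lower from compound 1 to compound 3 (beyond the scatter).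

The next compound is compound 4, `Cc1ccsc1-c1nc(CNc2ccc(C(=O)NO)cc2)n(-c2ccccc2)n1`. It differs from compound 3 in one place: 3-methylthiophen-2-yl in place of 4-(trifluoromethyl)phenyl on an aromatic carbon. Among the measured compounds shown here, the step that bears most on this is the one from compound 2 to compound 3, in which a five-membered aromatic ring with one hetero atom gave way to a six-membered ring of carbon only and the read-out fell by a modest amount. For the measured compounds named here, compound 4 brings back a five-membered ring with one hetero atom, so a modest rise in this assay is expected, though no step for a thiophene itself has been measured. Compound 4 is therefore estimated at 55%, within 35% to 75%, an expected step of a number 13.4 percentage points higher from compound 3 to compound 4 (beyond the scatter).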

Compound 4, a percentage reported as inhibition, at one concentration (the size of the read-out at that concentration, not a potency): 72.1%
Compound 4: middle estimate off by 17.1 percentage points, on the low side; the measured number falls inside the stated range.
By their numbers in this assay, from the lowest: compound 3; then compound 2; then compounds 4 and 1 (each within the scatter of the next).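

Among the compounds shown here, the 3-methylthiophen-2-yl group is the first five-membered ring at this position to give a read-out level with the 4-methoxyphenyl group in this assay: the change is a number 5.5 percentage points lower from compound 1 to compound 4 (within the scatter). Ring size alone therefore does not set the read-out here: compound 4 compares with another five-membered ring with one hetero atom as a number 16.3 percentage points higher from compound 2 to compound 4 (beyond the scatter), and with a six-membered ring of carbon only as a number 30.5 percentage points higher from compound 3 to compound 4 (beyond the scatter), yet compound 1 also carries a six-membered ring of carbon only. Nothing available explains these differences.

As far as these compounds go, it remains open how a plain thiophen-2-yl ring, without the methyl group, would compare with compound 4. Also open, from the compounds shown here alone, is what an amine or a carboxylic acid on this ring would do to the read-out.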